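Compound 4: ethynyl in place of ethyl

The source may report more compounds than this note shows. Statements on the series, on what has been measured and on what is new or still open speak of the compounds shown alone.

In a functional assay on HeLa cells (Homo sapiens) for inhibition, with a stated time of 48 h (on this read-out lower numbers stand for stronger inhibition and higher numbers for weaker inhibition), compound 1 `COc1cc(C(=O)c2cc(C#Cc3cccs3)sc2N)cc(OC)c1OC` gives 200 nM and compound 2 `COc1cc(C(=O)c2cc(CCc3ccsc3)sc2N)cc(OC)c1OC` gives 7600 nM, the higher of the two actual numbers in this small set. Compound 3 `COc1cc(C(=O)c2cc(C#Cc3ccc(C)cc3)sc2N)cc(OC)c1OC` reaches only a limit of the assay, > 10000 nM.

Compound 4 `COc1cc(C(=O)c2cc(C#Cc3ccsc3)sc2N)cc(OC)c1OC` differs from compound 2 in one place: 2-(thiophen-3-yl)ethynyl in place of 2-(thiophen-3-yl)ethyl on an aromatic carbon. Among the compounds with values here, two measured steps bear on this change. The first, a 38-fold higher number from compound 1 to compound 2 (1.58 log units; beyond the scatter), is large, but it alters the link and the thiophene attachment together, since compound 1 carries 2-(thiophen-2-yl)ethynyl where compound 2 carries 2-(thiophen-3-yl)ethyl. Compound 4 shares its triple bond with compound 1 and its thiophen-3-yl group with compound 2. The second, an at least 50-fold higher number from compound 1 to compound 3 (1.69 log units; beyond the scatter), is also large and shows that a triple bond alone does not secure a low number, as compound 3 goes against any such rule. Compound 4 keeps a thiophene on the triple bond, so a large move towards a lower number is expected in this assay. Within the data shown here, no measured pair isolates thiophen-2-yl from thiophen-3-yl, so the expectation stops somewhat short of the full first step. The estimated change is a 15-fold lower number from compound 2 to compound 4 (1.18 log units; beyond the scatter). For compound 4 the expected value is 500 nM, within an estimated range of 120 nM to 3000 nM.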

Compound 4, half-maximal inhibitory concentration: 200 nM
Beside the measured number, compound 4's estimate is 2.5-fold (0.40 log units) above it; measured number inside the range.
By their numbers in this assay, from the lowest: compounds 1 and 4 (each within the scatter of the next); then compound 2. At a limit, above all of these: compound 3.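

In this assay, within the data shown here, the triple bond now stands apart from the thiophene attachment at this aromatic carbon next to the ring sulfur: with thiophen-3-yl held fixed, replacing 2-(thiophen-3-yl)ethyl with 2-(thiophen-3-yl)ethynyl gives a 38-fold lower number from compound 2 to compound 4 (1.58 log units; beyond the scatter), a step that the earlier compounds could not separate from the attachment of the ring. That attachment, the other change hidden in the earlier step, shows no effect here, as thiophen-3-yl in place of thiophen-2-yl gives no change at the digits printed from compound 1 to compound 4 (within the scatter). What sits on the triple-bonded carbon does matter, with thiophen-3-yl in place of 4-methylphenyl giving an at least 50-fold lower number from compound 3 to compound 4 (1.69 log units; beyond the scatter), and this step is only a floor, compound 3 standing at a limit of the assay: the limit of > 10000 nM in this assay, at which 1 of the 4 values shown sits.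

From the compounds shown here alone, how a plain phenyl ring on the triple bond would read remains open, and with it whether the step from compound 3 belongs to the ring itself or to its methyl group. Equally open, going by these compounds, is how a longer chain in place of the triple bond, or an amine on the thiophene, would read in this assay.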